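This account rests on a few compounds, and the source may have more. Where it says the series, first, only, none or still open, it means among the compounds named here.

Measured compounds:
compound 1 `Clc1cccc(-c2cc(-c3ccoc3)cc(-c3ccc(Cl)s3)n2)c1`: 950 nM
compound 2 `Clc1ccc(-c2cc(-c3ccoc3)cc(-c3ccc(Cl)s3)n2)cc1`: 640 nM
compound 3 `Clc1cccc(-c2cc(-c3ccc(Cl)o3)cc(-c3ccc(Cl)s3)n2)c1`: a limit, > 50000 nM

In a functional assay on HCT-15 cells (Homo sapiens) for cytotoxicity, read by ELISA, with a stated time of 4 days (on this read-out lower numbers stand for stronger inhibition and higher numbers for weaker inhibition), compound 1 gives 950 nM and compound 2 gives 640 nM; the step is a 1.5-fold lower number from compound 1 to compound 2 (0.17 log units; within the scatter), the change being (4-chlorophenyl in place of 3-chlorophenyl on an aromatic carbon). Compound 3 is recorded in this assay only as a limit, > 50000 nM (the limit of > 50000 nM in this assay, at which 1 of the 3 values shown sits). From the core of compound 1 to compound 3 the step is an at least 52-fold higher number from compound 1 to compound 3 (1.72 log units; beyond the scatter), the difference being (5-chlorofuran-2-yl in place of furan-3-yl on an aromatic carbon). Compound 4 `Clc1ccc(-c2cc(-c3ccc(Cl)o3)cc(-c3ccc(Cl)s3)n2)cc1` awaits measurement in this assay; it differs from compound 3 by 4-chlorophenyl in place of 3-chlorophenyl on an aromatic carbon. This is the same kind of change as from compound 1 to compound 2, but around the place a 5-chlorofuran-2-yl group stands where compound 1 carries a furan-3-yl group. For compound 4 a step of a number no higher from compound 3 to compound 4 (the limit leaves the size open) is expected in this assay, resting on the step of a 1.5-fold lower number from compound 1 to compound 2 (0.17 log units; within the scatter) lying within the scatter. Compound 4 is therefore estimated in this assay at 50000 nM, with a range from 20000 nM to 200000 nM, and most likely again only a limit.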

Compound 4, half-maximal inhibitory concentration: 25300 nM
Estimate against measurement, compound 4: 2.0-fold (0.30 log units) above; the measured number falls inside the stated range.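

The change from 3-chlorophenyl to 4-chlorophenyl gives an at least 1.9-fold lower number from compound 3 to compound 4 (0.29 log units; that floor lies within the scatter) in this assay, and nothing here separates it from the same change on the core of compound 1: the same change on two cores in this assay, a 1.5-fold lower number (0.17 log units; within the scatter) from compound 1 to compound 2 and an at least 1.9-fold lower number (0.29 log units; that floor lies within the scatter) from compound 3 to compound 4; the limit leaves it open whether they differ

The change from furan-3-yl to 5-chlorofuran-2-yl carries over as a large rise in the number with either chlorophenyl group, a 40-fold higher number from compound 2 to compound 4 (1.60 log units; beyond the scatter): the same change on two cores in this assay, an at least 52-fold higher number (1.72 log units; beyond the scatter) from compound 1 to compound 3 and a 40-fold higher number (1.60 log units; beyond the scatter) from compound 2 to compound 4; the limit leaves it open whether they differ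

Compound 3 is only a limit, so the exact size of each step involving it is not shown: the limit of > 50000 nM in this assay, at which 1 of the 4 values shown sits.

As far as these compounds go, whether the rise follows the added chlorine or the different furan attachment stays open, since the two travel together in both pairs. Also open, from the compounds shown here alone, is how the series responds to an amine or a carboxylic acid on the furan.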